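This account rests on a few compounds, and the source may have more. Where it says the series, first, only, none or still open, it means among the compounds named here.

Measured compounds:
Compound 1, `Cc1nc(C)n(CC(=O)N2CCN(c3sc(C(F)(F)F)nc3-c3cnc(OC(C)C)nc3)C[C@H]2C)n1`, gives 3.4 nM.
Compound 2, `Cc1ncc(-c2nc(C(F)(F)F)sc2N2CCN(C(=O)Cn3nc(C)nc3C)[C@H](C)C2)cn1`, gives 19 nM.

Within the data shown here, in a functional assay on CHO-K1 cells for antagonist activity at C-X-C chemokine receptor type 3 (Homo sapiens), read by FLIPR, with a stated time of 10 min (a higher number here means a weaker inhibitor, a lower number a stronger inhibitor), compound 2 stands as the weaker of the two measured compounds: compound 1 gives the lower number, and the one measured step, a 5.6-fold higher number from compound 1 to compound 2 (0.75 log units; beyond the scatter), is a modest loss that lies beyond the scatter.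

Compound 3, `CCc1ncc(-c2nc(C(F)(F)F)sc2N2CCN(C(=O)Cn3nc(C)nc3C)[C@H](C)C2)cn1`, has not yet been measured. It differs from compound 2 in one place: methyl in place of hydrogen on a saturated chain carbon bound to an aromatic carbon, so the methyl becomes an ethyl and the 2-methylpyrimidin-5-yl becomes a 2-ethylpyrimidin-5-yl.

Among the measured compounds shown here, no measured step changes exactly this spot in this way. For the measured compounds named here, the only step that touches the same aromatic carbon, a 5.6-fold higher number from compound 1 to compound 2 (0.75 log units; beyond the scatter), concerns the larger isopropoxy group rather than ethyl, so it bears on compound 3 only loosely. Since adding one carbon is a far smaller change than that swap, the expected step in this assay is small, and a move of a size within the scatter or a slight gain is the most reasonable expectation.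

Compound 3 is therefore estimated at 13 nM, with a likely range from 4 nM to 40 nM, which corresponds to an expected step of a 1.5-fold lower number from compound 2 to compound 3 (0.16 log units; within the scatter).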

Compound 3, half-maximal inhibitory concentration: 14 nM
Beside the measured number, compound 3's estimate is 1.1-fold (0.03 log units) below it; low and high end bracket the measured number.
By their numbers in this assay, from the lowest: compound 1; then compounds 3 and 2 (each within the scatter of the next).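

In this assay, extending the 2-methylpyrimidin-5-yl to a 2-ethylpyrimidin-5-yl gives a 1.4-fold lower number from compound 2 to compound 3 (0.13 log units; within the scatter), so adding a methyl on this saturated chain carbon bound to an aromatic carbon does not separate the two compounds. The earlier comparison set methyl against isopropoxy, and the new one shows that the gap remains when ethyl stands in place of methyl: the swap of isopropoxy for ethyl gives a 4.1-fold higher number from compound 1 to compound 3 (0.61 log units; beyond the scatter), a modest step that lies beyond the scatter. Among the three groups seen at this aromatic carbon, methyl and ethyl thus sit together and isopropoxy stands apart, although nothing shown here offers an explanation for this.

Isopropoxy differs from ethyl both in its oxygen and in its branching, so these compounds cannot say which of the two features goes with the lower number. An ethoxy or methoxy group would test the oxygen without the branching, an isopropyl group would test the branching without the oxygen, and a longer chain such as propyl would show whether the flat response continues beyond ethyl.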